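The compounds below may be only part of what the source reports. "The series", "measured", "known", "first", "only" and "open" are said of these compounds alone.

Compound 1 `Cc1c(Cc2c(Cl)cccc2Cl)nc(SCC(=O)c2ccccc2)[nH]c1=O`, compound 2 `CCc1c(Cc2c(Cl)cccc2Cl)nc(SCC(=O)c2ccccc2)[nH]c1=O` and compound 3 `CCc1c(Cc2c(F)cccc2Cl)nc(SCC(=O)c2ccccc2)[nH]c1=O` are the measured members of this set, and compound 4 `CC(C)c1c(Cc2c(F)cccc2Cl)nc(SCC(=O)c2ccccc2)[nH]c1=O` is the one still to be tested. In an ADME assay on MT4 cells (Homo sapiens) for cytotoxicity, read by MTT assay (a higher number here means that more compound is tolerated, a lower number that less compound is tolerated), compound 1 gives > 60000 nM, which is a limit of the assay rather than a number. Compound 2 likewise gives only a limit, > 52000 nM, in this assay. Compound 3 gives a limit as well, > 12000 nM. The difference from compound 1 to compound 2 is methyl in place of hydrogen on a saturated chain carbon bound to an aromatic carbon, and the step that the two limits leave unreadable from compound 1 to compound 2 cannot be read because the limit of > 60000 nM in this assay, at which 1 of the 3 values shown sits, and the limit of > 52000 nM in this assay, at which 1 of the 3 values shown sits, are both limits. The step that the two limits leave unreadable from compound 2 to compound 3 is equally unreadable. The difference between the core of compound 1 and the core of compound 3 is not broken down here.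

Compound 4 differs from compound 3 by methyl in place of hydrogen on a saturated chain carbon bound to an aromatic carbon and a saturated chain carbon. For the measured compounds named here, this is the same kind of change as the one from compound 1 to compound 2, though the place differs: here the saturated chain carbon is bound to an aromatic carbon and a saturated chain carbon, whereas there it was bound to an aromatic carbon only. Because (the limit of > 12000 nM in this assay, at which 1 of the 3 values shown sits), the limit of > 52000 nM in this assay, at which 1 of the 3 values shown sits, and the limit of > 60000 nM in this assay, at which 1 of the 3 values shown sits, are all limits, the step that the limit leaves unreadable from compound 3 to compound 4 in this assay is expected to be small. Compound 4 is therefore expected to give about 40000 nM, within 10000 nM to 150000 nM, and most likely to be reported again only as a limit.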

Compound 4, half-maximal cytotoxic concentration: > 12000 nM
Compound 4 gave a limit, no number (the forecaster's own chance of this, stated with the estimate: 80%); the middle value lies beyond the limit too.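

In this assay compound 4 gives only a limit, > 12000 nM, and compound 3 also has a limit, so no step can be read between compound 3 and compound 4: the limit of > 12000 nM in this assay, at which 2 of the 4 values shown sit.

The compounds shown leave open the half-maximal cytotoxic concentration of all four compounds, and whether ethyl to isopropyl changes it at all.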